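Chloro on the Benzoate of a Basic Analogue

The source may hold more compounds than are shown below. What is called first, only, known or untested is meant among the compounds shown, and "the series" means these compounds.

Compound 1, `O=C1CCCC/C1=C\c1ccc(OC(=O)c2ccccc2)cc1`: in a functional assay on P388 cells (Mus musculus) (a lower number here means a stronger inhibitor, a higher number a weaker inhibitor), compound 1 gives > 50000 nM, which is a limit of the assay and not a number.
Compound 2, `O=C1CCCC/C1=C\c1ccc(OC(=O)c2ccc(Cl)cc2)cc1`: compound 2 gives 25500 nM.
Compound 3, `CN(C)CC1CCC/C(=C\c2ccc(OC(=O)c3ccccc3)cc2)C1=O`: compound 3 gives 180 nM.

Compound 3 has the lowest number of the three, with compound 2 far above it. Two single changes have been measured. From compound 1 to compound 2 the change is chloro in place of hydrogen on an aromatic carbon; it gave an at least 1.9-fold lower number from compound 1 to compound 2 (0.29 log units; that floor lies within the scatter). Compound 1 sits at the limit of > 50000 nM in this assay, at which 1 of the 3 values shown sits, so only the floor of that step is known, and that floor lies within the usual scatter. The cores of compound 1 and compound 3 differ by (dimethylamino)methyl in place of hydrogen on a saturated ring carbon, which gave an at least 270-fold lower number from compound 1 to compound 3 (2.44 log units; beyond the scatter).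

Compound 4, `CN(C)CC1CCC/C(=C\c2ccc(OC(=O)c3ccc(Cl)cc3)cc2)C1=O`, has not yet been measured. It differs from compound 3 by chloro in place of hydrogen on an aromatic carbon, the same change made from compound 1 to compound 2, at a place described in the same words. For the measured compounds named here, the one earlier example of this change rests on a limit, so its true size is uncertain. Compound 4 is expected to show a 1.5-fold lower number from compound 3 to compound 4 (0.18 log units; within the scatter) in this assay, a small change at most, since the earlier step gave an at least 1.9-fold lower number from compound 1 to compound 2 (0.29 log units; that floor lies within the scatter). Compound 4 is therefore estimated at 120 nM, most likely falling from 45 nM to 400 nM.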

Compound 4, half-maximal inhibitory concentration: 425 nM
The estimate for compound 4 lay 3.5-fold (0.55 log units) below the measured number; the whole stated range lies below it.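

In this assay, chloro in place of hydrogen on an aromatic carbon did not carry over from one core to the other: on the basic core it gave a 2.4-fold higher number from compound 3 to compound 4 (0.37 log units; beyond the scatter), and the two examples of the change disagree: the same change on two cores in this assay, an at least 1.9-fold lower number (0.29 log units; that floor lies within the scatter) from compound 1 to compound 2 and a 2.4-fold higher number (0.37 log units; beyond the scatter) from compound 3 to compound 4, at least 4.6-fold (0.66 log units) apart, beyond the scatter of two such steps

The (dimethylamino)methyl group, by contrast, lowered the number on both cores, with a 60-fold lower number from compound 2 to compound 4 (1.78 log units; beyond the scatter), though the size of the step was not the same: the same change on two cores in this assay, an at least 270-fold lower number (2.44 log units; beyond the scatter) from compound 1 to compound 3 and a 60-fold lower number (1.78 log units; beyond the scatter) from compound 2 to compound 4, at least 4.6-fold (0.66 log units) apart, beyond the scatter of two such steps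

Compound 1 gives > 50000 nM, which is a limit of the assay and not a number, and these two pairs do not show why the chloro step differs between the cores or how it would behave on a third core.

The compounds shown leave open whether the higher number of compound 4 is particular to chloro or would also appear with another group on the benzoate, such as fluoro, bromo or methoxy. They also leave open whether the large gain from (dimethylamino)methyl would persist with a different amine, such as piperidine or morpholine, or with a longer chain carrying the amine.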